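This account rests on a few compounds, and the source may have more. Where it says the series, first, only, none or still open, it means among the compounds named here.

Compound 1 `c1ccc(Sc2ncnc3[nH]cnc23)cc1`: 0%
Compound 2 `Fc1ccc(Cn2cnc3c(Cl)ncnc32)cc1`: 0%

In an assay on isolated protein for inhibition of RAC-alpha serine/threonine-protein kinase (Homo sapiens), tested at 30 uM (a lower number here means less inhibition, a higher number more inhibition at the concentration tested (going by the name of the read-out)), compound 1 gives 0%. Compound 2 stands level with compound 1 at the digits shown, within the scatter, and in this assay compound 2 gives 0%. Compound 3 `Fc1ccc(Cn2cnc3c(Sc4ccccc4)ncnc32)cc1` differs from compound 2 by phenylsulfanyl in place of chloro on an aromatic carbon. For the measured compounds named here, no step between measured compounds is available here, so the size of this change is not anchored. Since compound 1 carries the same phenylsulfanyl group and gives 0%, the step of no change at the digits printed from compound 2 to compound 3 (within the scatter) is expected to be none beyond the scatter. Compound 3 is therefore estimated at 0%, within -10% to 12%.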

Compound 3, a percentage reported as inhibition, at one concentration (the size of the read-out at that concentration, not a potency): 13%
For compound 3 the middle estimate is 13 percentage points below the measured one, and the stated range ends below it.
By their numbers in this assay, from the lowest: compounds 1 and 2 (each within the scatter of the next); then compound 3.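

In this assay, phenylsulfanyl in place of chloro on an aromatic carbon gives a number 13 percentage points higher from compound 2 to compound 3 (beyond the scatter), and 4-fluorobenzyl in place of hydrogen on an aromatic nitrogen gives a number 13 percentage points higher from compound 1 to compound 3 (beyond the scatter). Each group thus registers only when the other is present, and the two steps remain modest. No available evidence explains this.

Going by these compounds, whether an amine nitrogen or an ether oxygen could take the place of the sulfur remains open. So does whether a plain benzyl group would serve as well as 4-fluorobenzyl.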